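The source may report more compounds than this note shows. Statements on the series, on what has been measured and on what is new or still open speak of the compounds shown alone.

For the measured compounds named here, in a functional assay on MDA-MB-231 cells (Homo sapiens) for cytotoxicity, read by MTT assay, with a stated time of 72 h (a lower number here means a stronger inhibitor, a higher number a weaker inhibitor), compound 2 `O=C(CN1CCN(c2nnc(Cc3ccccc3)c3ccccc23)CC1)Nc1ccc(F)c(F)c1` gives 2750 nM, the highest number of the three measured so far, which makes it the weakest inhibitor among them. Compound 1 `O=C(CN1CCN(c2nnc(Cc3ccncc3)c3ccccc23)CC1)Nc1ccc(Br)cc1` gives 19 nM and compound 3 `Cc1ccc(F)cc1NC(=O)CN1CCN(c2nnc(Cc3ccncc3)c3ccccc23)CC1` gives 6.4 nM, both far lower, although each differs from compound 2 in more than one place. The next structure, compound 4 `O=C(CN1CCN(c2nnc(Cc3ccccc3)c3ccccc23)CC1)Nc1cccc(F)c1`, departs from compound 2 in a single place: hydrogen in place of fluoro on an aromatic carbon. Hydrogen stands in place of fluoro on an aromatic carbon, so 3,4-difluorophenyl becomes 3-fluorophenyl.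

Going by the values given here, no measured pair makes this exact change. The nearest evidence is a swap of one whole substituted phenyl for another on the amide-type nitrogen, a 3.0-fold lower number from compound 1 to compound 3 (0.47 log units; beyond the scatter), and that step was only modest. Losing one fluoro is a smaller edit, so a step no larger than that one is expected in this assay, with no clear direction and possibly none beyond the scatter. The estimated step is a 1.2-fold lower number from compound 2 to compound 4 (0.08 log units; within the scatter). For compound 4 the expected value is 2300 nM, with an estimated range of 700 nM to 7500 nM.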

Compound 4, half-maximal inhibitory concentration: 3730 nM
Estimate against measurement, compound 4: 1.6-fold (0.21 log units) below; the range from low to high includes it.
By their numbers in this assay, from the lowest: compound 3; then compound 1; then compounds 2 and 4 (each within the scatter of the next).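

In this assay, removing the fluoro that sits para to a large group turns 3,4-difluorophenyl into 3-fluorophenyl and gives a 1.4-fold higher number from compound 2 to compound 4 (0.13 log units; within the scatter). For the compounds shown here, this is the first direct reading of this position, and it shows that this one fluoro can be replaced by hydrogen without a change that stands out from the scatter, as long as the other fluoro stays on the ring. Nothing available explains this result or shows what the fluoro does there. As far as these compounds go, whether a different group at this position, such as chloro, methoxy or an amine, would move the number beyond the scatter remains open. From the compounds shown here alone, it is also open whether removing the remaining fluoro, leaving an unsubstituted phenyl, would change the number.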